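Removing the chloro group from an oxazole carboxamide

A few compounds are considered here, and "the series" means these few. Any claim that something is new, unique, unknown or untested is made for them only; others in the source may bear on it.

In a functional assay on HL-60 cells (Homo sapiens) for inhibition, read by MTT assay, with a stated time of 72 h (on this read-out higher numbers stand for weaker inhibition and lower numbers for stronger inhibition), two compounds have been measured. Compound 1 `Cc1nc(-c2ccccc2)c(C(=O)N2CCN(c3cccc(F)c3)CC2)o1` gives 45 nM, and compound 2 `Cc1ccc(C)c(N2CCN(C(=O)c3oc(C)nc3-c3cccc(Cl)c3)CC2)c1` gives 345 nM, the higher of the two numbers and thus the weaker inhibitor, a gap beyond the usual scatter. Compound 3 `Cc1ccc(C)c(N2CCN(C(=O)c3oc(C)nc3-c3ccccc3)CC2)c1` is compound 2 with a single change: hydrogen in place of chloro on an aromatic carbon. Compound 1 also carries a phenyl rather than a 3-chlorophenyl, yet it differs from compound 2 in a second place as well, so its stronger inhibition cannot be traced to that ring alone. For compound 3 a step of a 1.2-fold lower number from compound 2 to compound 3 (0.06 log units; within the scatter) is expected, with no direction beyond the scatter. Compound 3 is estimated at 300 nM, within 100 nM to 1000 nM.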

Compound 3, half-maximal inhibitory concentration: 31.3 nM
Compound 3: the middle estimate sits 9.6-fold (0.98 log units) above what was measured; the measured number lies below the stated range.
By their numbers in this assay, from the lowest: compounds 3 and 1 (each within the scatter of the next); then compound 2.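

In this assay the change from 3-chlorophenyl to phenyl proves large, with an 11-fold lower number from compound 2 to compound 3 (1.04 log units; beyond the scatter), so with the 2,5-dimethylphenyl group in place, the chloro group on this ring weakens inhibition. With phenyl kept, 2,5-dimethylphenyl in place of 3-fluorophenyl on the amine nitrogen gives a 1.4-fold lower number from compound 1 to compound 3 (0.16 log units; within the scatter), a step that stays within the scatter. Nothing measured here accounts for the large step. Going by these compounds, whether a methyl or methoxy group at the chloro position would match chloro or hydrogen remains open. So does whether removing chloro has the same effect with 3-fluorophenyl on the amine nitrogen.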